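Dimethylamino for Methoxy on the Furan Analogue

The compounds below may be only part of what the source reports. "The series", "measured", "known", "first", "only" and "open" are said of these compounds alone.

Compound 1 `COc1ncnc2c1c(-c1ccsc1)cn2[C@@H]1O[C@H](CO)[C@@H](O)[C@H]1O`: in a functional assay on HepG2 cells (Homo sapiens) for antiproliferative activity, read by XTT assay, with a stated time of 72 h (on this read-out higher numbers stand for weaker inhibition and lower numbers for stronger inhibition), compound 1 gives 430 nM.
Compound 2 `CN(C)c1ncnc2c1c(-c1ccsc1)cn2[C@@H]1O[C@H](CO)[C@@H](O)[C@H]1O`: compound 2 gives > 20000 nM, which is a limit of the assay rather than a number.
Compound 3 `COc1ncnc2c1c(-c1ccoc1)cn2[C@@H]1O[C@H](CO)[C@@H](O)[C@H]1O`: compound 3 gives 290 nM.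

Compound 3 differs from compound 1 by furan-3-yl in place of thiophen-3-yl on an aromatic carbon, and this gave a 1.5-fold lower number from compound 1 to compound 3 (0.17 log units; within the scatter). The change from compound 1 to compound 2 is dimethylamino in place of methoxy on an aromatic carbon; it gave an at least 46-fold higher number from compound 1 to compound 2 (1.66 log units; beyond the scatter), ending at the limit of > 20000 nM in this assay, at which 1 of the 3 values shown sits.

Compound 4 `CN(C)c1ncnc2c1c(-c1ccoc1)cn2[C@@H]1O[C@H](CO)[C@@H](O)[C@H]1O` is not yet measured. It differs from compound 3 by dimethylamino in place of methoxy on an aromatic carbon, the same change in the same place, now on the core of compound 3. Because compound 1 and compound 2 show an at least 46-fold higher number from compound 1 to compound 2 (1.66 log units; beyond the scatter), a step of about a 69-fold higher number from compound 3 to compound 4 (1.84 log units; beyond the scatter) is expected for compound 4. Compound 4 is therefore estimated at about 20000 nM, probably again reported only as a limit, within 7000 nM to 60000 nM.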

Compound 4, half-maximal inhibitory concentration: 12500 nM
Compound 4: middle estimate off by 1.6-fold (0.20 log units), on the high side, and the stated range covers the measured number.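

In this assay, dimethylamino in place of methoxy gives a 43-fold higher number from compound 3 to compound 4 (1.63 log units; beyond the scatter), so the number rises strongly on both cores shown: the same change on two cores in this assay, an at least 46-fold higher number (1.66 log units; beyond the scatter) from compound 1 to compound 2 and a 43-fold higher number (1.63 log units; beyond the scatter) from compound 3 to compound 4; the limit leaves it open whether they differ. Furan-3-yl in place of thiophen-3-yl on the dimethylamino compounds gives an at least 1.6-fold lower number from compound 2 to compound 4 (0.20 log units; that floor lies within the scatter), and the value of compound 2 is a limit of the assay and not a number: the same change on two cores in this assay, a 1.5-fold lower number (0.17 log units; within the scatter) from compound 1 to compound 3 and an at least 1.6-fold lower number (0.20 log units; that floor lies within the scatter) from compound 2 to compound 4; the limit leaves it open whether they differ. The large rise therefore carries over between these two closely related cores, but this does not show that its size is identical, or that it would hold on any other core.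

The compounds shown leave open how a smaller group in place of methoxy, such as methylamino or a plain amine, would behave. They also leave open whether the same rise appears with a phenyl ring in place of the furan-3-yl or thiophen-3-yl group.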